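Trifluoromethyl in place of methyl in compound 4

This account rests on a few compounds, and the source may have more. Where it says the series, first, only, none or still open, it means among the compounds named here.

compound 1 `COc1cc(/C=C/c2ccc(C)cc2)c(-c2ccccc2)c(OC)c1OC` gives 31000 nM
compound 2 `C=C(c1ccccc1)c1cc(OC)c(OC)c(OC)c1-c1ccccc1` gives 34000 nM
compound 3 `C=C(c1ccc(C)cc1)c1cc(OC)c(OC)c(OC)c1-c1ccccc1` gives 31000 nM

In a functional assay on SK-N-SH cells (Homo sapiens) for cytotoxicity, read by MTT assay, with a stated time of 48 h (on this read-out higher numbers stand for weaker inhibition and lower numbers for stronger inhibition), compound 3 (31000 nM) stands level with compound 1 (31000 nM) at the digits shown, and the remaining gap is a 1.1-fold lower number from compound 2 to compound 3 (0.04 log units; within the scatter) in size. Compound 4 `C=C(c1ccc(C(F)(F)F)cc1)c1cc(OC)c(OC)c(OC)c1-c1ccccc1` follows from compound 3 by one change, trifluoromethyl in place of methyl on an aromatic carbon, para to a large group trifluoromethyl in place of methyl on an aromatic carbon in the counted terms. For the measured compounds named here, no measured compound carries trifluoromethyl, so the data hold no direct test of this group. The nearest evidence is methyl in place of hydrogen, which gave a 1.1-fold lower number from compound 2 to compound 3 (0.04 log units; within the scatter) as its step. The two changes in the ethenyl link gave a 1.1-fold higher number from compound 1 to compound 2 (0.04 log units; within the scatter) and no change at the digits printed from compound 1 to compound 3 (within the scatter) as their steps. None of these three steps leaves the scatter, which gives no ground for expecting a shift in either direction. The step expected in this assay is a 1.0-fold lower number from compound 3 to compound 4 (0.01 log units; within the scatter) and no larger than the usual scatter. Compound 4 is therefore estimated at 30000 nM (expected range 14000 nM to 60000 nM).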

Compound 4, half-maximal inhibitory concentration: 13000 nM
Estimate against measurement, compound 4: 2.3-fold (0.36 log units) above; the measured number lies below the stated range.
By their numbers in this assay, from the lowest: compound 4; then compounds 1, 3 and 2 (each within the scatter of the next).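

In this assay this aromatic carbon, para to a large group, had shown no shift beyond the scatter, as methyl in place of hydrogen gave only a 1.1-fold lower number from compound 2 to compound 3 (0.04 log units; within the scatter) as its step. Trifluoromethyl now gives a 2.4-fold lower number from compound 3 to compound 4 (0.38 log units; beyond the scatter) and, against hydrogen, a 2.6-fold lower number from compound 2 to compound 4 (0.42 log units; beyond the scatter) in the same place, so the position does respond to the group it carries, though both steps are modest and compound 4 alone stands apart from the others. Nothing measured in these compounds accounts for this shift.

The compounds shown leave open whether chlorine, a nitrile or a methoxy group on this carbon would side with compound 4 or with compounds 2 and 3. They also leave open whether trifluoromethyl would give a similar step on the ethenyl link of compound 1.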